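From Ethyl to Isopropyl on Compound 2

The source may hold more compounds than are shown below. What is called first, only, known or untested is meant among the compounds shown, and "the series" means these compounds.

Going by the values given here, in a functional assay on the whole organism with Rattus norvegicus as the target (a higher number here means that more compound is needed for the effect, a lower number that less compound is needed), compound 2 `CCOC(=O)C(=O)Nc1cccc(N(C)CC)c1C#N` gives 0.5 mg/kg and holds the higher of the two numbers so far, while compound 1 `CCNc1cccc(NC(=O)C(=O)OCC)c1C#N` gives 0.03 mg/kg on the same scale. Compound 3 `CCOC(=O)C(=O)Nc1cccc(N(C)C(C)C)c1C#N` turns the ethyl of compound 2 into isopropyl: methyl in place of hydrogen on a saturated chain carbon bound to a nitrogen on an aromatic ring and a saturated chain carbon in the chain on the nitrogen. Among the compounds with values here, only one measured step bears on this, a large one with methyl in place of hydrogen on that nitrogen: a 17-fold higher number from compound 1 to compound 2 (1.22 log units; beyond the scatter) in this series. The new methyl sits on a different atom, so a smaller rise is expected, an estimated 3.0-fold higher number from compound 2 to compound 3 (0.48 log units; beyond the scatter) in the same direction. Compound 3 is estimated at 1.5 mg/kg with an expected range of 0.4 mg/kg to 6 mg/kg for this measurement.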

Compound 3, dose for half-maximal effect: 1.2 mg/kg
The estimate for compound 3 lay 1.3-fold (0.10 log units) above the measured number, within the range that was stated.
By their numbers in this assay, from the lowest: compound 1; then compound 2; then compound 3.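

In this assay, the saturated chain carbon bound to the nitrogen also responds to a methyl, with a 2.4-fold higher number from compound 2 to compound 3 (0.38 log units; beyond the scatter) as its step, which is smaller than a 17-fold higher number from compound 1 to compound 2 (1.22 log units; beyond the scatter) for the methyl on the nitrogen itself. Replacing ethylamino with isopropyl(methyl)amino gives a 40-fold higher number from compound 1 to compound 3 (1.60 log units; beyond the scatter) overall, so both methyls move the number the same way. No measurement here explains these rises.
Isopropylamino remains open, and it would separate the branch from the methyl on the nitrogen. On these data alone, a longer chain, such as propyl, or a cyclopropyl group at this place also remains open.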